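Compound 3 to compound 4: a tetrazole on a methyl link

The source may hold more compounds than are shown below. What is called first, only, known or untested is meant among the compounds shown, and "the series" means these compounds.

Measured in an ADME assay on microsomes from liver (Mus musculus) for metabolic stability; a higher number here means that the compound lasts longer, a lower number that the compound disappears faster:
- compound 1 `CC(C)C(c1ccc(-c2ccc3cccc(F)c3c2)[nH]c1=O)N1CCCCC1=O`: 0.0967 h
- compound 2 `CC(C)C(Cc1noc(=O)[nH]1)c1ccc(-c2ccc3cccc(F)c3c2)[nH]c1=O`: 2.78 h
- compound 3 `CC(C)C(c1ncc[nH]1)c1ccc(-c2ccc3cccc(F)c3c2)[nH]c1=O`: < 0.0667 h, a limit of the assay

Compound 3 has no exact number, only (the limit of < 0.0667 h in this assay, at which 1 of the 3 values shown sits). It cannot be ranked against compound 1, since an at least 1.4-fold lower number from compound 1 to compound 3 (0.16 log units; that floor lies within the scatter). Compound 2 lies far from it, with an at least 41-fold lower number from compound 2 to compound 3 (1.61 log units; beyond the scatter).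

Compound 4 `CC(C)C(Cc1nnn[nH]1)c1ccc(-c2ccc3cccc(F)c3c2)[nH]c1=O` is the next compound, and it carries (1H-tetrazol-5-yl)methyl in place of 1H-imidazol-2-yl on a saturated chain carbon bound to an aromatic carbon and a saturated chain carbon.

For the measured compounds named here, two measured steps bear on this change. The closer guide is an at least 41-fold lower number from compound 2 to compound 3 (1.61 log units; beyond the scatter), where the group of compound 2, with one five-membered aromatic ring with 3 hetero atoms, gives way to the 1H-imidazol-2-yl of compound 3. The entering group of compound 4 looks more like the group of compound 2 than like the group it replaces. The step of a 29-fold higher number from compound 1 to compound 2 (1.46 log units; beyond the scatter) shows the same high value of compound 2 against compound 1. A large rise in this assay is therefore expected, though the two rings differ and part of the gain may not carry over. The expected change is an estimated at least 29-fold higher number from compound 3 to compound 4 (1.47 log units; beyond the scatter), upward and beyond the scatter. For compound 4 the half-life is estimated at 2 h, with an expected range of 0.5 h to 6 h.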

Compound 4, half-life: 0.853 h
Compound 4: the middle estimate sits 2.3-fold (0.37 log units) above what was measured, within the range that was stated.
By their numbers in this assay, from the lowest: compound 1; then compound 4; then compound 2. At a limit, below all of these: compound 3.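

In this assay, the change at this saturated chain carbon gives an at least 12-fold higher number from compound 3 to compound 4 (1.10 log units; beyond the scatter), a step that starts from a limit of the assay and so gives only a floor for the rise. The five-membered aromatic ring on a methyl link does not set the value by that arrangement alone, as changing the ring with 3 hetero atoms to the 1H-tetrazol-5-yl ring gives a 3.3-fold lower number from compound 2 to compound 4 (0.51 log units; beyond the scatter), so the identity of the ring counts here even with the link kept. The comparison with the 2-oxopiperidin-1-yl group gives an 8.8-fold higher number from compound 1 to compound 4 (0.95 log units; beyond the scatter), which makes compound 4 the second compound with a ring on a methyl link to stand clear of compound 1, although it stays short of compound 2.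

Going by these compounds, no ring appears here both with and without the methyl link, so the shares of the link and of the ring in the rise from compound 3 remain open. On these data alone, it is also open where a carboxylic acid on the same link, or a longer chain carrying the 1H-tetrazol-5-yl ring, would fall relative to compound 2 and compound 4.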